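The source may hold more compounds than are shown below. What is called first, only, known or untested is meant among the compounds shown, and "the series" means these compounds.

Working notes on the series. In a functional assay on A549 cells (Homo sapiens) for antiproliferative activity, read by CCK-8 assay, with a stated time of 72 h (a lower number here means a stronger inhibitor, a higher number a weaker inhibitor), compound 3 `Cc1cc(C(=O)Nc2cccc(-c3oc4cc(-c5ccc(F)cc5)ccc4c(=O)c3O)c2)ccc1F` gives 11500 nM, the second highest of the three numbers shown, though its gaps to both neighbours lie within the scatter. Compound 2 `O=C(Nc1cccc(-c2oc3cc(-c4ccc(F)cc4)ccc3c(=O)c2O)c1)c1cccc(F)c1` gives 15400 nM and compound 1 `O=C(Nc1cccc(-c2oc3cc(-c4ccc(F)cc4)ccc3c(=O)c2O)c1)c1ccc(F)cc1` gives 6930 nM. The change to compound 4 `O=C(Nc1cccc(-c2oc3cc(-c4ccc(F)cc4)ccc3c(=O)c2O)c1)c1ccc([N+](=O)[O-])cc1` is 4-nitrophenyl in place of 4-fluoro-3-methylphenyl on a carbonyl carbon. The measured steps at this same carbonyl carbon bear on it: a 2.2-fold higher number from compound 1 to compound 2 (0.35 log units; beyond the scatter), a 1.3-fold lower number from compound 2 to compound 3 (0.13 log units; within the scatter) and a 1.7-fold higher number from compound 1 to compound 3 (0.22 log units; within the scatter). Going by the values given here, these are modest or within the scatter, and no measured step introduces a nitro group, so the direction cannot be read from the series. The expected step is therefore small, a 1.2-fold lower number from compound 3 to compound 4 (0.06 log units; within the scatter). Compound 4 is estimated at 10000 nM, with a range from 3500 nM to 30000 nM.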

Compound 4, half-maximal inhibitory concentration: 2440 nM
Compound 4: the middle estimate sits 4.1-fold (0.61 log units) above what was measured; the whole stated range lies above it.
By their numbers in this assay, from the lowest: compound 4; then compounds 1, 3 and 2 (each within the scatter of the next, the first and the last beyond it).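

In this assay, the group on this carbonyl carbon moves the number further than the earlier fluorinated phenyl groups did: nitro in place of fluoro on an aromatic carbon gives a 2.8-fold lower number from compound 1 to compound 4 (0.45 log units; beyond the scatter). The other two exchanges are larger, a 4.7-fold lower number from compound 3 to compound 4 (0.67 log units; beyond the scatter) and a 6.3-fold lower number from compound 2 to compound 4 (0.80 log units; beyond the scatter), all beyond the scatter, which puts compound 4 lowest of the four. Nothing available accounts for this gain.

Open, from the compounds shown here alone, is whether the gain is specific to nitro: a nitrile, an amine or a carboxylic acid on the same aromatic carbon would test that.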